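Butoxy in place of methyl on the lead sulfonyl compound

The source may hold more compounds than are shown below. What is called first, only, known or untested is meant among the compounds shown, and "the series" means these compounds.

Among the compounds with values here, in a functional assay on MOLT-4 cells (Homo sapiens) for cytotoxicity (on this read-out lower numbers stand for stronger inhibition and higher numbers for weaker inhibition), compound 1 (`Cc1ccc(S(=O)(=O)N/C(=N\O)Nc2ccc(Cl)cc2)cc1`) gives 6 ug/mL, the lowest number among the three compounds measured so far. Compound 2 (`Cc1c(S(=O)(=O)N/C(=N\O)Nc2ccc(Cl)cc2)sc2ccc(Cl)cc12`) reads 38 ug/mL and compound 3 (`O=[N+]([O-])c1ccc(Oc2c(Cl)cc(S(=O)(=O)N/C(=N\O)Nc3ccc(Cl)cc3)cc2Cl)cc1`) reads 55 ug/mL, both beyond the scatter from compound 1 and so weaker in this assay.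

Compound 4 (`CCCCOc1ccc(S(=O)(=O)N/C(=N\O)Nc2ccc(Cl)cc2)cc1`) carries butoxy in place of methyl on an aromatic carbon, para to a large group: butoxy in place of methyl on an aromatic carbon. Within the data shown here, no measured pair differs in one place only, so no direct step is available as a guide, and the basis for any expectation is thin. Compound 2 at 38 ug/mL and compound 3 at 55 ug/mL both differ from compound 1 in the group on the sulfonyl, and neither matches it. With only these two examples, a move towards weaker inhibition seems more likely than a gain, though a smaller one, as the change here is limited to a single substituent.

The estimated step is a 3.3-fold higher number from compound 1 to compound 4 (0.52 log units; beyond the scatter), expected to lie beyond the scatter. Compound 4 is expected at 20 ug/mL, within an estimated range of 7 ug/mL to 55 ug/mL.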

Compound 4, half-maximal inhibitory concentration: 18 ug/mL
Compound 4: middle estimate off by 1.1-fold (0.05 log units), on the high side; low and high end bracket the measured number.
By their numbers in this assay, from the lowest: compound 1; then compound 4; then compounds 2 and 3 (each within the scatter of the next).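

Within the data shown here, this is the first step that changes one place only: in this assay, butoxy in place of methyl on an aromatic carbon, para to a large group, gives a 3.0-fold higher number from compound 1 to compound 4 (0.48 log units; beyond the scatter). The position therefore accepts the longer group with its added hydrogen-bond acceptor, at the price of a modest loss of inhibition rather than a gain. Among these compounds, nothing measured so far offers an explanation for this step.

As far as these compounds go, a single step cannot separate the contribution of the oxygen from that of the chain, so methoxy and a plain butyl group at this position remain open comparisons. The compounds shown also leave open how an amine or a carboxylic acid on this aromatic carbon would read, and whether any group here could match or improve on methyl.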